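The source may report more compounds than this note shows. Statements on the series, on what has been measured and on what is new or still open speak of the compounds shown alone.

Of the compounds shown here, three sharing one core have been measured in a functional assay on MGC-803 cells (Homo sapiens) for cytotoxicity, read by MTT assay, with a stated time of 72 h; on this read-out lower numbers stand for stronger inhibition and higher numbers for weaker inhibition. Compound 1 `FC(F)(F)c1ccc(CSc2nc(Nc3cccc(C(F)(F)F)c3)c3ccccc3n2)cc1` gives 15100 nM, compound 2 `FC(F)(F)c1ccc(CSc2nc(Nc3cccc(Cl)c3)c3ccccc3n2)cc1` gives 14600 nM, and compound 3 `O=[N+]([O-])c1ccc(Nc2nc(SCc3ccc(C(F)(F)F)cc3)nc3ccccc23)cc1` gives 8170 nM. Compound 3 thus shows the lowest of the three numbers, yet its gaps to the others are small: a 1.8-fold lower number from compound 1 to compound 3 (0.27 log units; within the scatter) and a 1.8-fold lower number from compound 2 to compound 3 (0.25 log units; within the scatter), and likewise a 1.0-fold lower number from compound 1 to compound 2 (0.01 log units; within the scatter). Compound 4 `Cc1ccc(Nc2nc(SCc3ccc(C(F)(F)F)cc3)nc3ccccc23)cc1` is not yet measured. It differs from compound 3 by methyl in place of nitro on an aromatic carbon. Going by the values given here, no measured step replaces a nitro group by a methyl group, so the only guidance comes from the three steps above, each of which alters the substituent on this phenyl ring and each of which stays within the scatter. On that basis the step from compound 3 to compound 4 in this assay is expected to be small, with no clear direction, and is estimated as a 1.3-fold higher number from compound 3 to compound 4 (0.13 log units; within the scatter). For compound 4 the expected value in this assay is 11000 nM, with a range from 4000 nM to 30000 nM.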

Compound 4, half-maximal inhibitory concentration: 36100 nM
Compound 4: middle estimate off by 3.3-fold (0.52 log units), on the low side, and the stated range ends below it.
By their numbers in this assay, from the lowest: compounds 3, 2 and 1 (each within the scatter of the next); then compound 4.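

Among the changes on this aryl group, methyl in place of nitro is the first to move the number in this assay beyond the scatter (a 4.4-fold higher number from compound 3 to compound 4 (0.65 log units; beyond the scatter)). Compound 4 also stands apart from the two compounds with a different aryl group on that nitrogen (a 2.5-fold higher number from compound 2 to compound 4 (0.39 log units; beyond the scatter)) and (a 2.4-fold higher number from compound 1 to compound 4 (0.38 log units; beyond the scatter)), so the 4-methylphenyl group does not join the earlier three, which all lay within the scatter of one another. No measurement given here accounts for this shift.

Going by these compounds, what remains open is whether the higher number of compound 4 comes from losing the nitro group or from adding the methyl group. An amine, a methoxy group or a carboxylic acid on the same aromatic carbon, or an unsubstituted phenyl ring, would help to separate those two readings.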